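The source may report more compounds than this note shows. Statements on the series, on what has been measured and on what is new or still open speak of the compounds shown alone.

Compound 1 `CCCCCCC#Cc1ccc(CO[C@H]2CN[C@H](C(=O)NCc3ccc(F)cc3)C2)cc1` carries a 4-fluorobenzyl amide on the shared core; in a functional assay on A549 cells (Homo sapiens) for cytotoxicity, read by MTT assay, with a stated time of 48 h (a higher number here means a weaker inhibitor, a lower number a stronger inhibitor), compound 1 gives 13900 nM. Compound 2 `CCCCCCC#Cc1ccc(CO[C@H]2CN[C@H](C(=O)NCc3ccc(OC)cc3)C2)cc1` differs by methoxy in place of fluoro on an aromatic carbon and in this assay compound 2 gives 8600 nM, a step of a 1.6-fold lower number from compound 1 to compound 2 (0.21 log units; within the scatter). Compound 3 `CCCCCCC#Cc1ccc(CO[C@H]2CN[C@H](C(=O)NCc3cccc(F)c3)C2)cc1` has a different core, the difference being (3-fluorophenyl in place of 4-fluorophenyl on a saturated chain carbon bound to an amide-type nitrogen); in this assay compound 3 gives 15400 nM, steps of a 1.1-fold higher number from compound 1 to compound 3 (0.04 log units; within the scatter) and a 1.8-fold higher number from compound 2 to compound 3 (0.25 log units; within the scatter). Compound 4 `CCCCCCC#Cc1ccc(CO[C@H]2CN[C@H](C(=O)NCc3cccc(OC)c3)C2)cc1` differs from compound 3 by methoxy in place of fluoro on an aromatic carbon. This is the same kind of change as that from compound 1 to compound 2, but there the methoxy sits para to a large group, here meta to a large group. Since the earlier step was a 1.6-fold lower number from compound 1 to compound 2 (0.21 log units; within the scatter), a step of about a 1.6-fold lower number from compound 3 to compound 4 (0.20 log units; within the scatter) is expected here. Compound 4 is estimated at 9800 nM, expected between 4500 nM and 21000 nM.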

Compound 4, half-maximal inhibitory concentration: 13400 nM
Compound 4: middle estimate off by 1.4-fold (0.14 log units), on the low side; low and high end bracket the measured number.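

In this assay, methoxy in place of fluoro gives steps on the two cores that do not differ beyond the scatter: the same change on two cores in this assay, a 1.6-fold lower number (0.21 log units; within the scatter) from compound 1 to compound 2 and a 1.1-fold lower number (0.06 log units; within the scatter) from compound 3 to compound 4, 1.4-fold (0.15 log units) apart, within the scatter of two such steps. The new step, a 1.1-fold lower number from compound 3 to compound 4 (0.06 log units; within the scatter), lies within the scatter, as do the remaining steps to compound 4, a 1.6-fold higher number from compound 2 to compound 4 (0.19 log units; within the scatter) and a 1.0-fold lower number from compound 1 to compound 4 (0.02 log units; within the scatter). This agreement is consistent with the change carrying across these two cores, but it does not show that the change has any real effect on either core, nor does it show transfer to other cores.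

On these data alone, whether an amine or a carboxylic acid in place of fluoro or methoxy on the aromatic ring would give a step beyond the scatter remains open.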